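Methoxy gives way to methylsulfanyl on the five-membered ring

The compounds below may be only part of what the source reports. "The series", "measured", "known", "first", "only" and "open" are said of these compounds alone.

Three compounds on one shared core were tested in a functional assay on the whole organism (6C3HED cells, Mus musculus) for inhibition, at a dose of 150 mg/kg by the oral route; a higher number here means more inhibition at the dose given (going by the name of the read-out), a lower number less inhibition. Compound 1 `O=C(Nc1ccc(Cl)cc1)NS(=O)(=O)c1cccs1` gives 16%, compound 2 `O=C(Nc1ccc(Cl)cc1)NS(=O)(=O)c1ccc(Cl)s1` gives 58%, and compound 3 `COc1ccc(S(=O)(=O)NC(=O)Nc2ccc(Cl)cc2)s1` gives 93%, the highest of the three, since a number 35 percentage points higher from compound 2 to compound 3 (beyond the scatter) and a number 77 percentage points higher from compound 1 to compound 3 (beyond the scatter) are both beyond the scatter. Compound 4 `CSc1ccc(S(=O)(=O)NC(=O)Nc2ccc(Cl)cc2)s1` differs from compound 3 by methylsulfanyl in place of methoxy on an aromatic carbon. Among the compounds with values here, no measured step exchanges methoxy for methylsulfanyl. The steps that change the group on that aromatic carbon, a number 42 percentage points higher from compound 1 to compound 2 (beyond the scatter) and a number 35 percentage points higher from compound 2 to compound 3 (beyond the scatter), show that the group there moves the read-out strongly, so a shift in either direction is possible, with little room upward. Compound 4 is expected to give 75%, between 45% and 95%, an estimated a number 18 percentage points lower from compound 3 to compound 4 (beyond the scatter).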

Compound 4, a percentage reported as inhibition, in the whole organism at one dose (the size of the read-out at that dose, not a potency): 29%
Compound 4: the middle estimate sits 46 percentage points above what was measured; the whole stated range lies above it.
By their numbers in this assay, from the lowest: compound 1; then compound 4; then compound 2; then compound 3.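

In this assay the position does not treat methoxy and methylsulfanyl alike, though the two groups have the same counts of heavy atoms and hydrogen-bond acceptors (a number 64 percentage points lower from compound 3 to compound 4 (beyond the scatter)). Methylsulfanyl also stays short of chloro (a number 29 percentage points lower from compound 2 to compound 4 (beyond the scatter)) and keeps only a modest gain over hydrogen (a number 13 percentage points higher from compound 1 to compound 4 (beyond the scatter)), so a group on this carbon does not by itself secure a high read-out. No measurement on hand accounts for the gap between the oxygen and sulfur groups. The compounds shown leave open how ethoxy, a longer chain on the oxygen, or an amine on this carbon would read in this assay.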